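Cytotoxicity of a Fourth Thiophene-Benzothiazole Imine

The source may hold more compounds than are shown below. What is called first, only, known or untested is meant among the compounds shown, and "the series" means these compounds.

Measured compounds:
compound 1, `Clc1ccc(/C=N/c2sc3c(c2-c2nc4ccccc4s2)CCCC3)c(Cl)c1`, 384 ug/mL
compound 2, `Clc1ccccc1/C=N/c1sc2c(c1-c1nc3ccccc3s1)CCCC2`, 370 ug/mL
compound 3, `C(=C/c1ccccc1)\C=N\c1sc2c(c1-c1nc3ccccc3s1)CCCC2`, 467 ug/mL

All three were tested in an ADME assay on HepG2 cells (Homo sapiens) for cytotoxicity, read by MTT assay, with a stated time of 72 h; on this read-out higher numbers stand for lower toxicity in this test and lower numbers for higher toxicity in this test. Compound 3 gives the largest of the three numbers, but the gaps are small: a 1.2-fold higher number from compound 1 to compound 3 (0.08 log units; within the scatter) and a 1.3-fold higher number from compound 2 to compound 3 (0.10 log units; within the scatter). The shared core of compounds 1, 2 and 3 carries a benzothiazole ring with no substituent, and the compounds differ only at the imine substituent.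

Compound 4, `Clc1ccc2sc(-c3c(/N=C/C=C/c4ccccc4)sc4c3CCCC4)nc2c1`, has not yet been tested in this assay. It differs from compound 3 in one place: chloro in place of hydrogen on an aromatic carbon. Among the compounds with values here, the only measured step that concerns a chloro group is a 1.0-fold lower number from compound 1 to compound 2 (0.02 log units; within the scatter), where a chloro on the imine aryl ring was removed with no change beyond the scatter. That step sits on a different ring from the one altered here, so it bears on the present change only loosely. Within the data shown here, still, it is the single guide available, and none of the three measured steps moves the cytotoxic concentration beyond the scatter.

Compound 4 is therefore expected to show a step of a 1.1-fold lower number from compound 3 to compound 4 (0.04 log units; within the scatter), that is, no change beyond the scatter. The estimate for compound 4 in this assay is 430 ug/mL, with a range from 250 ug/mL to 700 ug/mL.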

Compound 4, half-maximal cytotoxic concentration: 114 ug/mL
Beside the measured number, compound 4's estimate is 3.8-fold (0.58 log units) above it; measured number below the stated range.
By their numbers in this assay, from the lowest: compound 4; then compounds 2, 1 and 3 (each within the scatter of the next).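

In this assay, within the data shown here, chloro in place of hydrogen on the six-membered aromatic ring of carbon only, part of a fused system, is not a silent change: it gives a 4.1-fold lower number from compound 3 to compound 4 (0.61 log units; beyond the scatter), the only step in this set that lies beyond the scatter, and it points toward higher toxicity in this test. Among these compounds, the earlier compounds gave no sign of this, since their only chloro step involved a chloro on the imine aryl ring, and the size of this exchange turns out to differ with where it is made: the same change on two cores in this assay, a 1.0-fold lower number (0.02 log units; within the scatter) from compound 1 to compound 2 and a 4.1-fold higher number (0.61 log units; beyond the scatter) from compound 4 to compound 3, 4.3-fold (0.63 log units) apart, beyond the scatter of two such steps This position on the fused system is thus the first place where a single added atom moves the read-out beyond the scatter, while the imine substituent changes seen so far did not.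

As far as these compounds go, whether this shift belongs to chloro itself or would also appear with a methoxy group, an amine or a carboxylic acid at the same carbon remains open. Also open, from the compounds shown here alone, is whether chloro would give a step of this size with the 2-chlorophenyl or 2,4-dichlorophenyl imine substituent in place of 2-phenylethenyl.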